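Isopropoxy in place of methylamino on the shared core

The source may hold more compounds than are shown below. What is called first, only, known or untested is meant among the compounds shown, and "the series" means these compounds.

Among the compounds with values here, compound 2 `CNc1cccc(NC(=O)C(=O)O)c1C#N` gives the higher of the two numbers measured so far in a functional assay on the whole organism for inhibition, with Rattus norvegicus as the target, at a dose of 1 mg/kg by the oral route (a lower number here means less inhibition, a higher number more inhibition at the dose given (going by the name of the read-out)), at 96%. Within the data shown here, its only neighbour on the shared core, compound 1 `CN(C)c1cccc(NC(=O)C(=O)O)c1C#N`, gives 54.7% in this assay. Among the measured compounds shown here, the single measured step, a number 41.3 percentage points higher from compound 1 to compound 2 (beyond the scatter), came from hydrogen in place of methyl on a nitrogen on an aromatic ring and was large.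

Compound 3 `CC(C)Oc1cccc(NC(=O)C(=O)O)c1C#N` differs from compound 2 by isopropoxy in place of methylamino on an aromatic carbon. For the measured compounds named here, no measured step exchanges a nitrogen-bearing group for an oxygen-bearing one at this place, so the only guide is how strongly the read-out answered to a change at that same nitrogen, where the step was a number 41.3 percentage points higher from compound 1 to compound 2 (beyond the scatter). Compound 3 removes the methylamino group altogether and puts in its place a group with one hydrogen-bond acceptor and no hydrogen-bond donor, larger by two heavy atoms. Compound 3 is therefore expected to lose inhibition, by a step of a number 46 percentage points lower from compound 2 to compound 3 (beyond the scatter), with wide uncertainty. The estimate for compound 3 in this assay is 50%, within a range from 15% to 85%.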

Compound 3, a percentage reported as inhibition, in the whole organism at one dose (the size of the read-out at that dose, not a potency): 75.1%
Compound 3: middle estimate off by 25.1 percentage points, on the low side; the measured number falls inside the stated range.
By their numbers in this assay, from the lowest: compound 1; then compound 3; then compound 2.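

In this assay, the aromatic carbon ortho to a cyano group keeps a substantial read-out without any nitrogen attached there: isopropoxy in place of methylamino gives a number 20.9 percentage points lower from compound 2 to compound 3 (beyond the scatter) and isopropoxy in place of dimethylamino gives a number 20.4 percentage points higher from compound 1 to compound 3 (beyond the scatter), two modest steps in opposite directions. The earlier pair had shown only that the read-out answers to a change at the nitrogen, whereas the oxygen-bearing group now falls between the two nitrogen-bearing groups, so exchanging nitrogen for oxygen at this place does not by itself set the direction of the step. No measurement bearing on the reason for this order is available.

From the compounds shown here alone, how the read-out would answer to an unsubstituted amine, or to a shorter ether such as methoxy or ethoxy, at this place remains open, and these could show whether the size of the group or the atom attached to the ring tracks more closely with the order. The three numbers also describe inhibition at a single oral dose, so how the compounds would rank at other doses is left open as well.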